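Para-Chloro Substitution on the Benzyl Ring of Compound 3

A few compounds are considered here, and "the series" means these few. Any claim that something is new, unique, unknown or untested is made for them only; others in the source may bear on it.

Measured compounds:
compound 1, `CC(C(=O)NCc1cccc(Cl)c1)N1C(=O)CCC1=O`, 82 mg/kg
compound 2, `CC(C(=O)NCc1ccc(C(F)(F)F)cc1)N1C(=O)CCC1=O`, 80.1 mg/kg
compound 3, `CCC(C(=O)NCc1ccccc1)N1C(=O)CCC1=O`, 73.3 mg/kg

Of the compounds shown here, three sharing one core have been measured in a functional assay on the whole organism (strain Albino Swiss CD1) with Mus musculus as the target, in the maximal electroshock model; a higher number here means that more compound is needed for the effect, a lower number that less compound is needed. Compound 3 gives 73.3 mg/kg, the smallest number of the three, yet the gaps to compound 2 at 80.1 mg/kg and to compound 1 at 82 mg/kg both fall within the usual scatter, so the three cannot be told apart on these numbers.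

Compound 4, `CCC(C(=O)NCc1ccc(Cl)cc1)N1C(=O)CCC1=O`, has not yet been measured in this assay. It differs from compound 3 by chloro in place of hydrogen on an aromatic carbon. Among the measured compounds shown here, no pair of measured compounds shows this single change, so its size is unknown from direct comparison. What the data do show is that compounds 1 and 2, which carry a chloro or a trifluoromethyl group on the same ring, give numbers within the scatter of compound 3. The step from compound 3 to compound 4 in this assay is therefore expected to be small, a 1.0-fold lower number from compound 3 to compound 4 (0.01 log units; within the scatter), not beyond the scatter in either direction. Compound 4 is estimated to give 72 mg/kg, in a range from 40 mg/kg to 130 mg/kg.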

Compound 4, dose for half-maximal effect: 95.4 mg/kg
Estimate against measurement, compound 4: 1.3-fold (0.12 log units) below, within the range that was stated.
By their numbers in this assay, from the lowest: compounds 3, 2, 1 and 4 (each within the scatter of the next).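

Among the compounds shown here, the first direct reading of chloro in place of hydrogen on an aromatic carbon, para to a large group, comes from this assay and reads a 1.3-fold higher number from compound 3 to compound 4 (0.11 log units; within the scatter) and so stays inside the usual spread of repeat measurements. On this one pair, going from phenyl to 4-chlorophenyl therefore cannot be said to raise or lower the dose needed, and the change is tolerated at this place without a readable effect. No measurement at hand speaks to why the number falls where it does.

Going by these compounds, whether a different group at the same place, such as a methoxy group, an amine or a carboxylic acid, would give a step beyond the scatter remains open. Also open, on these data alone, is whether chloro would give a similar step on a compound with a longer chain in place of the ethyl group.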